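This account rests on a few compounds, and the source may have more. Where it says the series, first, only, none or still open, it means among the compounds named here.

Measured compounds in a functional assay on MCF7 cells (Homo sapiens) for inhibition, read by MTT assay, with a stated time of 24 h; a higher number here means a weaker inhibitor, a lower number a stronger inhibitor:
- compound 1 `CCCCCCCCn1cc(COC2(C(F)(F)F)Oc3ccccc3C=C2C(=O)OCC)nn1` gives > 150000 nM; this is a limit of the assay, not a number.
- compound 2 `O=C(O)C1=Cc2ccccc2OC1(OCc1cc(-c2ccc([N+](=O)[O-])cc2)no1)C(F)(F)F` gives > 150000 nM; this too is a limit.

Compound 1 therefore stands at the limit of this assay, and there is no measured number anywhere in the series to set against it, since (the limit of > 150000 nM in this assay, at which 2 of the 2 values shown sit). Among the measured compounds shown here, no pair of measured compounds differs in a single place, so no measured step is available.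

Compound 3 `CCOC(=O)C1=Cc2ccccc2OC1(OCc1cn(CC(=O)Nc2cccc(F)c2)nn1)C(F)(F)F` is the next compound for this assay. It differs from compound 1 by (3-fluorophenyl)carbamoyl in place of heptyl on a saturated chain carbon bound to an aromatic nitrogen. With both shown values at the limit, the expectation for this change in this assay is no step beyond the scatter, and the most likely outcome is that compound 3 also reports only a limit. The step expected from compound 1 to compound 3 is a number no higher from compound 1 to compound 3 (the limit leaves the size open). Compound 3 is estimated at 150000 nM, with a range from 50000 nM to 500000 nM.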

Compound 3, half-maximal inhibitory concentration: > 150000 nM
Compound 3: only a limit was reported; the forecaster's own chance of this, stated with the estimate: 80%; the middle value lies on the limit itself.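

No step can be read from compound 1 to compound 3, since both report only a limit in this assay: the limit of > 150000 nM in this assay, at which 3 of the 3 values shown sit.

The compounds shown leave open whether any change on the shared core would give a measured number rather than a limit, and how large any difference between these compounds is.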